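The compounds below may be only part of what the source reports. "The series", "measured", "known", "first", "only" and "open" are said of these compounds alone.

Measured so far:
- compound 1 `O=C(OCCCCOc1ccccc1)c1cccc(=O)[nH]1`: 94000 nM
- compound 2 `O=C(OCc1cc(F)c(F)cc1F)c1cccc(=O)[nH]1`: 67000 nM

Both numbers come from an assay on isolated protein for inhibition of matrix metalloproteinase-9 (Homo sapiens); on this read-out lower numbers stand for stronger inhibition and higher numbers for weaker inhibition. On this read-out compound 1 and compound 2 sit inside the usual scatter of each other, so neither stands apart from the other; both show only weak inhibition, with half-maximal effect reached at high concentration.

Compound 3 `O=C(OCCCCOc1ccccc1)c1cccc(S)n1` has not yet been measured. It arises from compound 1 by a single change: a group of 7 heavy atoms (5 carbon, 1 nitrogen, 1 sulfur; one six-membered aromatic ring with 1 hetero atom) in place of a group of 7 heavy atoms (5 carbon, 1 nitrogen, 1 oxygen; one six-membered aromatic ring with 1 hetero atom), on a carbonyl carbon. Among the measured compounds shown here, no step between two measured compounds resembles this exchange, so there is nothing in the data to calibrate it against. Any expectation for compound 3 therefore rests on compound 1 alone, whose value of 94000 nM is the starting point.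

In this assay a step of moderate size toward stronger inhibition is expected for this exchange, although a step that stays inside the scatter cannot be ruled out. The estimated step is a 3.1-fold lower number from compound 1 to compound 3 (0.50 log units; beyond the scatter). Compound 3 is expected to give 30000 nM, with a plausible range from 6000 nM to 150000 nM.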

Compound 3, half-maximal inhibitory concentration: 83000 nM
For compound 3 the middle estimate is 2.8-fold (0.44 log units) below the measured one; low and high end bracket the measured number.
By their numbers in this assay, from the lowest: compounds 2, 3 and 1 (each within the scatter of the next).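

Among the compounds shown here, exchanging the oxygen-bearing six-membered aromatic ring of compound 1 for 6-sulfanylpyridin-2-yl, on a carbonyl carbon, gives a 1.1-fold lower number from compound 1 to compound 3 (0.05 log units; within the scatter) in this assay and so provides the first step here that can be read as a change in one place. Compounds 1 and 2 could not offer this, since they have the same ring and differ elsewhere, whereas this pair shows that, with the rest of compound 1 kept intact, putting sulfur where the oxygen stood leaves the result indistinguishable from ordinary repeat variation, and inhibition remains weak. Nothing measured here offers an explanation for this outcome.

From the compounds shown here alone, whether a different group at this place, such as an amine or a carboxylic acid, would give a number clearly apart from that of compound 1 remains open. Also open, going by these compounds, is whether the same exchange would behave similarly on compound 2, whose trifluorinated benzyl ester differs from the longer phenoxy-ending chain of compound 1.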